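Series notes: compound 2 to compound 4

This account rests on a few compounds, and the source may have more. Where it says the series, first, only, none or still open, it means among the compounds named here.

Measured so far in a functional assay on HeLa cells (Homo sapiens) for cytotoxicity, read by MTT assay, with a stated time of 72 h; on this read-out higher numbers stand for weaker inhibition and lower numbers for stronger inhibition:
compound 1 `O=C(/C=C/c1cccc(Cl)c1Cl)Nc1cc2c(Nc3ccc(F)c(Cl)c3)ncnc2cc1O[C@H]1CCOC1` gives 30500 nM
compound 2 `N#Cc1ccc(/C=C/C(=O)Nc2cc3c(Nc4ccc(F)c(Cl)c4)ncnc3cc2O[C@H]2CCOC2)cc1` gives "not determined" (no result reported)
compound 3 `COc1cc2ncnc(Nc3ccc(F)c(Cl)c3)c2cc1NC(=O)/C=C/c1ccc(C#N)cc1` gives "not determined" (no result reported)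

Compound 2 cannot be placed on the numbers, since it has no result, and the same holds for compound 3. Within the data shown here, the only anchor is compound 1 (30500 nM). Next is compound 4 `O=C(/C=C/c1ccccc1[N+](=O)[O-])Nc1cc2c(Nc3ccc(F)c(Cl)c3)ncnc2cc1O[C@H]1CCOC1`. The change 2-nitrophenyl in place of 4-cyanophenyl on a double-bonded chain carbon bound to a double-bonded chain carbon puts 2-nitrophenyl in place of 4-cyanophenyl on a double-bonded chain carbon bound to a double-bonded chain carbon. Among the measured compounds shown here, no measured step exists to size this change, so no shift beyond the usual scatter is expected in this assay, in either direction, from the level of compound 1 (30500 nM). The estimated value for compound 4 is 20000 nM (expected range 6000 nM to 60000 nM).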

Compound 4, half-maximal inhibitory concentration: 29600 nM
Compound 4: middle estimate off by 1.5-fold (0.17 log units), on the low side, within the range that was stated.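

In this assay the exchange of 2,3-dichlorophenyl for 2-nitrophenyl on a double-bonded chain carbon bound to a double-bonded chain carbon reads as a 1.0-fold lower number from compound 1 to compound 4 (0.01 log units; within the scatter). Among these compounds, this is the first exchange at this position that can be sized, and these two aryl groups are not told apart by this read-out. Nothing on hand accounts for this result.

Compound 2 and compound 3 have no result, so 4-cyanophenyl remains unplaced. Open, on these data alone, is whether an amine or a carboxylic acid at this place would shift the read-out.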